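The compounds below may be only part of what the source reports. "The series", "measured", "known", "first", "only" and "open" are said of these compounds alone.

Measured in an ADME assay on EA.hy 926 cells (Homo sapiens) for inhibition, read by sulforhodamine B assay, with a stated time of 72 h; a lower number here means a stronger inhibitor, a higher number a weaker inhibitor:
- compound 1 `CCCNC(=C\C(=O)/C=C/c1ccc(O)c(OC)c1)/C=C/c1ccc(O)c(OC)c1`: > 25000 nM
- compound 2 `CC(=O)Oc1ccc(/C=C/C(=O)/C=C(/C=C/c2ccc(OC(C)=O)cc2)NCC(C)C)cc1`: > 25000 nM
- compound 3 `CCC(C)NC(=C\C(=O)/C=C/c1ccc(OC(C)=O)c(OC)c1)/C=C/c1ccc(OC(C)=O)c(OC)c1`: > 25000 nM

Compound 1 gives > 25000 nM, which is a limit of the assay and not a number. Among the compounds with values here, compound 2 and compound 3 stand at the same limit, so the series offers (the limit of > 25000 nM in this assay, at which 3 of the 3 values shown sit), and no measured compound has a numerical value. Within the data shown here, no step between measured compounds is available to size a structural change.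

Compound 4 `CCCCNC(=C\C(=O)/C=C/c1ccc(O)c(OC)c1)/C=C/c1ccc(O)c(OC)c1` keeps the core of compound 1 and differs in one place: methyl in place of hydrogen on a saturated chain carbon, three bonds along the chain from an amine nitrogen. In words, this is methyl in place of hydrogen on a saturated chain carbon, three bonds along the chain from an amine nitrogen, so the chain goes from propyl to butyl.

The expectation rests on compound 1, whose reading is the limit > 25000 nM. In this assay, no change beyond the scatter is expected, and the expected step is a number no higher from compound 1 to compound 4 (the limit leaves the size open). A further limit reading is the likeliest outcome. Compound 4 is estimated at 25000 nM, with an expected range of 10000 nM to 50000 nM.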

Compound 4, half-maximal inhibitory concentration: > 25000 nM
Compound 4 gave a limit, no number; the forecaster's own chance of this, stated with the estimate: 75%; the middle value sits exactly at the limit.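

No step can be read between compound 1 and compound 4: both readings in this assay are limits, not numbers. The compounds shown leave open how the amine chain or any other structural change affects inhibition, with every reading at one value: the limit of > 25000 nM in this assay, at which 4 of the 4 values shown sit.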